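Chloro for fluoro on the aryl group: cytotoxicity notes

The compounds below may be only part of what the source reports. "The series", "measured", "known", "first", "only" and "open" are said of these compounds alone.

Measured in an ADME assay on J774.A1 cells (Mus musculus) for cytotoxicity, read by MTT assay, with a stated time of 72 h; on this read-out higher numbers stand for lower toxicity in this test and lower numbers for higher toxicity in this test:
- compound 1 `COc1ccc(-c2cc(-c3ccc(C4NC(=O)c5ccccc5N4)cc3)nc(N)n2)cc1`: 178000 nM
- compound 2 `COc1cccc(-c2cc(-c3ccc(C4NC(=O)c5ccccc5N4)cc3)nc(N)n2)c1OC`: > 400000 nM (a limit of the assay)
- compound 3 `Nc1nc(-c2ccc(F)cc2)cc(-c2ccc(C3NC(=O)c4ccccc4N3)cc2)n1`: "not determined" (no result reported)

Compound 3 has no number in this assay: its entry reads "not determined" (no result reported), so it gives no starting point on the scale. Compound 4 `Nc1nc(-c2ccc(Cl)cc2)cc(-c2ccc(C3NC(=O)c4ccccc4N3)cc2)n1` differs from compound 3 at one place, chloro in place of fluoro on an aromatic carbon, para to a large group.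

For the measured compounds named here, the one measured step, an at least 2.2-fold higher number from compound 1 to compound 2 (0.35 log units; beyond the scatter), changes a different group and involves no halogen, so it bears only loosely on this exchange. It does show that a substituent change on this aryl position can move the read-out, but it gives no size or direction for the present change. Going by the values given here, with no value for compound 3, no step can be sized, and no shift in either direction is expected. The nearest numerical anchor is compound 1 at 178000 nM.

For compound 4 the expected half-maximal cytotoxic concentration is 160000 nM, with an estimated range of 60000 nM to 400000 nM.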

Compound 4, half-maximal cytotoxic concentration: 82200 nM
The estimate for compound 4 lay 1.9-fold (0.29 log units) above the measured number; measured number inside the range.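

In this assay, for the compounds shown here, compound 4 gives the first number for a halogen on this aryl group, and it reads lower than either methoxy-bearing compound: a 2.2-fold lower number from compound 1 to compound 4 (0.34 log units; beyond the scatter) and an at least 4.8-fold lower number from compound 2 to compound 4 (0.68 log units; beyond the scatter). Both steps lie beyond the scatter, so among compound 1, compound 2 and compound 4, the 4-chlorophenyl group carries the lowest number and thus the highest toxicity in this test. The step from compound 2 is only a bound, since compound 2 is recorded at a limit of the assay rather than at a number: the limit of > 400000 nM in this assay, at which 1 of the 4 values shown sits.

The fluoro to chloro exchange itself remains unsized, as compound 3 has no reported result to set against compound 4. Also open, as far as these compounds go, is how a bromo group, an amine or a carboxylic acid on this aryl group would read.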